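Pyrrolidinyl for amino on the aminomethyl side chain

A few compounds are considered here, and "the series" means these few. Any claim that something is new, unique, unknown or untested is made for them only; others in the source may bear on it.

Measured so far:
compound 1 `Cc1nnc(CN)n1-c1ccc(Cl)cc1C(O)c1ccccc1` — 4 mg/kg
compound 2 `CN(C)Cc1nccn1-c1ccc(Cl)cc1C(=O)c1ccccc1Cl` — 1.8 mg/kg

In a functional assay on the whole organism (strain CF-1) for inhibition, with Mus musculus as the target (on this read-out lower numbers stand for an effect already at smaller amounts and higher numbers for an effect only at larger amounts of compound), compound 1 gives 4 mg/kg, the highest of the two numbers in hand. Within the data shown here, compound 2, which differs from it in several places at once, gives 1.8 mg/kg, a lower number that lies beyond the scatter; with no single-point step between the two, the pair shows only that a lower number is reachable.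

Compound 3 `Cc1nnc(CN2CCCC2)n1-c1ccc(Cl)cc1C(O)c1ccccc1` is the next single-point change from compound 1: pyrrolidin-1-yl in place of amino on a saturated chain carbon bound to an aromatic carbon. Among the measured compounds shown here, no measured pair of this kind exists in the set, so the expected size of the step in this assay rests on the two values alone. The expectation is a small move toward a lower number, possibly not beyond the scatter, giving an expected step of a 1.3-fold lower number from compound 1 to compound 3 (0.12 log units; within the scatter) from compound 1 to compound 3. For compound 3 the estimate in this assay is 3 mg/kg, with a range from 1.2 mg/kg to 8 mg/kg.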

Compound 3, dose for half-maximal effect: 14 mg/kg
Estimate against measurement, compound 3: 4.7-fold (0.67 log units) below; the whole stated range lies below it.
By their numbers in this assay, from the lowest: compound 2; then compound 1; then compound 3.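

On the saturated chain carbon bound to an aromatic carbon, the step from amino to pyrrolidin-1-yl in this assay gives a 3.5-fold higher number from compound 1 to compound 3 (0.54 log units; beyond the scatter), so the number at this position responds to the change, and in the direction of effect only at larger amounts. Among these compounds, this is the first single-point step, and the earlier pair, which differs in several places at once, could not tie any change in the number to this side chain. The change adds a five-membered non-aromatic ring and leaves no hydrogen-bond donor on the group, and this single step cannot separate those two differences, while nothing in hand gives a cause for the step.

Open, from the compounds shown here alone, is whether the higher number follows from any substitution on the amino nitrogen or only from the ring, which methylamino on the same chain carbon, set against piperidin-1-yl or morpholin-4-yl, would help to separate. Going by these compounds, with one step in hand, it also remains open whether the same change would move the number in the same direction on another core, such as that of compound 2.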